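Methoxy on the Core: From Compound 2 to Compound 3

The source may report more compounds than this note shows. Statements on the series, on what has been measured and on what is new or still open speak of the compounds shown alone.

Compound 1 `COc1ccc2c(c1)/C(=C/c1c(-c3ccncc3)nc3sccn13)C(=O)N2C`: 82400 nM
Compound 2 `COc1nc2sc(C)cn2c1/C=C1/C(=O)Nc2ccccc21`: 65200 nM

In a functional assay on NSCLC cells (Homo sapiens) for cytotoxicity, read by sulforhodamine B assay, with a stated time of 48 h (a higher number here means a weaker inhibitor of growth, a lower number a stronger inhibitor of growth), compound 2 gives the smaller of the two numbers, but its gap to compound 1 lies within the scatter, so the two cannot be told apart. Compound 3 `COc1ccc2c(c1)/C(=C\c1c(OC)nc3sc(C)cn13)C(=O)N2` has not been measured. It differs from compound 2 by methoxy in place of hydrogen on an aromatic carbon. Among the measured compounds shown here, no step between measured compounds is available, so the expectation rests on the change alone: a step of a 1.1-fold lower number from compound 2 to compound 3 (0.04 log units; within the scatter) is expected, not beyond the scatter, with no settled direction. Compound 3 is therefore estimated at 60000 nM, with a range from 25000 nM to 150000 nM.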

Compound 3, concentration for total growth inhibition: 58700 nM
Compound 3: the middle estimate sits 1.0-fold (0.01 log units) above what was measured, within the range that was stated.
By their numbers in this assay, from the lowest: compounds 3, 2 and 1 (each within the scatter of the next).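

In this assay, among the compounds shown here, the step of a 1.1-fold lower number from compound 2 to compound 3 (0.05 log units; within the scatter) gives the first reading at this position, and it shows that methoxy in place of hydrogen on this aromatic carbon leaves the two compounds indistinguishable. This one step says nothing about other groups at this carbon or about methoxy elsewhere on the ring. No measurement available here bears on the reason for this result.

From the compounds shown here alone, whether an amine, a carboxylic acid or a longer alkoxy chain at this carbon would give a step beyond the scatter remains open. Also open, going by these compounds, is whether methoxy at another aromatic carbon would do so.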